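A halogenated ring swap on a shared quinazoline-free core

The source may hold more compounds than are shown below. What is called first, only, known or untested is meant among the compounds shown, and "the series" means these compounds.

Measured compounds:
compound 1 `O=C(CSc1nc(Nc2ccccc2)c2ccccc2n1)Nc1ccccc1F` — 12400 nM
compound 2 `O=C(CSc1nc(Nc2ccccc2)c2ccccc2n1)Nc1ccccc1Cl` — 14600 nM
compound 3 `C=CC(=O)Nc1cccc(NC(=O)CSc2nc(Nc3cccc(F)c3)c3ccccc3n2)c1` — 5370 nM

In a functional assay on PC-3 cells (Homo sapiens) for inhibition, read by MTT assay, with a stated time of 72 h (a lower number here means a stronger inhibitor, a higher number a weaker inhibitor), compound 3 gives 5370 nM, the lowest of the three numbers, and its gap to compound 1 and to compound 2 lies beyond the scatter. Among the compounds with values here, the only single-point step among the measured compounds, a 1.2-fold higher number from compound 1 to compound 2 (0.07 log units; within the scatter), exchanges one halogen for another on the amide-side ring and does not leave the scatter.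

Compound 4 `C=CC(=O)Nc1cccc(NC(=O)CSc2nc(Nc3ccc(Cl)cc3)c3ccccc3n2)c1` differs from compound 3 in one place: 4-chlorophenyl in place of 3-fluorophenyl on a nitrogen on an aromatic ring. Within the data shown here, no measured step touches this ring or moves a substituent to another position on a ring, so the step of a 1.2-fold higher number from compound 1 to compound 2 (0.07 log units; within the scatter) is the nearest guide, and it was flat. The expected step is therefore small, with no clear direction: a 1.0-fold higher number from compound 3 to compound 4 (0.01 log units; within the scatter) is estimated. Compound 4 is expected to give about 5500 nM, with a range from 2200 nM to 14000 nM.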

Compound 4, half-maximal inhibitory concentration: 10800 nM
The estimate for compound 4 lay 2.0-fold (0.29 log units) below the measured number; the measured number falls inside the stated range.
By their numbers in this assay, from the lowest: compounds 3, 4, 1 and 2 (each within the scatter of the next, the first and the last beyond it).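

Within the data shown here, the step of a 2.0-fold higher number from compound 3 to compound 4 (0.30 log units; within the scatter) is the first reading in this assay of a change to the ring on the nitrogen, and it shows that this position accepts 4-chlorophenyl in place of 3-fluorophenyl without a difference that can be told from repeat-measurement noise. The earlier halogen step concerned the other ring, so this is new information about a separate part of the molecule. The change alters both the halogen and its place on the ring at once, so the two effects cannot be pulled apart here.

Going by these compounds, whether 3-chlorophenyl or 4-fluorophenyl would separate them, and whether an amine or a carboxylic acid on this ring would move the number beyond the scatter, remains open. Nothing available explains the size of this step.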